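A few compounds are considered here, and "the series" means these few. Any claim that something is new, unique, unknown or untested is made for them only; others in the source may bear on it.

In a functional assay on K562 cells (Homo sapiens) for cytotoxicity, read by MTT assay, with a stated time of 5 days (on this read-out higher numbers stand for weaker inhibition and lower numbers for stronger inhibition), compound 1 `COc1ccc(-c2cnnn2-c2cc(OC)c(OC)c(OC)c2)cc1N` gives 11 nM, and compound 2 `COc1ccc(Cn2nncc2-c2cc(OC)c(OC)c(OC)c2)cc1N` gives 730 nM. These two measured values show that the series can reach low numbers, though the two compounds do not sit at the same level.

Compound 3 `COc1ccc(-c2cn(-c3cc(OC)c(OC)c(OC)c3)nn2)cc1` gives > 10000 nM. This value is a limit of the assay and not a number, so compound 3 stands at the weak end of the values in hand, with its true level unknown.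

Compound 4 `COc1ccc(-c2cn(-c3cc(OC)c(OC)c(OC)c3)nn2)cc1O` comes from compound 3 through a single change: hydroxy in place of hydrogen on an aromatic carbon. In words, a hydroxy group takes the place of a hydrogen on an aromatic carbon.

Going by the values given here, no measured pair isolates this change, so its size cannot be read from the data. The expected direction in this assay is toward stronger inhibition, but only a moderate shift is anticipated. This rests loosely on compound 1 at 11 nM, which differs from compound 4 in more than one place and so offers no direct scale.

The expected change is an at least 3.3-fold lower number from compound 3 to compound 4 (0.52 log units; beyond the scatter), an estimate that starts from a limit and is therefore rough. Compound 4 is expected at 3000 nM, with an estimated range of 300 nM to 10000 nM.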

Compound 4, half-maximal inhibitory concentration: > 10000 nM
Compound 4: a limit, no number (the forecaster's own chance of this, stated with the estimate: 30%); at least 3.3-fold (0.52 log units) between middle value and limit.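

In this assay compound 4 gives > 10000 nM, a limit and not a number. No step can be read between compound 3 and compound 4 because both stand at the same limit: the limit of > 10000 nM in this assay, at which 2 of the 4 values shown sit.

The compounds shown leave open whether hydroxy in place of hydrogen on an aromatic carbon changes the true level of compound 3 at all.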